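Taking the methoxy off compound 2

The source may hold more compounds than are shown below. What is called first, only, known or untested is meant among the compounds shown, and "the series" means these compounds.

Of the compounds shown here, two have been measured in an ADME assay on HeLa cells (Homo sapiens) for cytotoxicity, with a stated time of 48 h; a lower number here means that less compound is tolerated, a higher number that more compound is tolerated. There, compound 1 `CCC(CC)O[C@@H]1C=C(C(=O)Nc2ccccc2)C[C@H](N)[C@H]1NC(C)=O` gives 375000 nM. Compound 2 `CCC(CC)O[C@@H]1C=C(C(=O)Nc2ccccc2OC)C[C@H](NC(=O)OC(C)(C)C)[C@H]1NC(C)=O` reads > 1000000 nM, which is a limit of the assay and not a number. Compound 2 therefore stands at the limit of > 1000000 nM in this assay, at which 1 of the 2 values shown sits, with no exact figure to start from.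

Compound 3 `CCC(CC)O[C@@H]1C=C(C(=O)Nc2ccccc2)C[C@H](NC(=O)OC(C)(C)C)[C@H]1NC(C)=O` differs from compound 2 in one place, with hydrogen in place of methoxy on an aromatic carbon, ortho to a large group: hydrogen in place of methoxy on an aromatic carbon. Going by the values given here, no measured pair isolates this change, so its size has to be judged without a direct precedent. In this assay, no step beyond the scatter is expected, and the estimated change is a number no higher from compound 2 to compound 3 (the limit leaves the size open). A reading at the same limit would fit this expectation. For compound 3 the estimated value is 1000000 nM, with an expected range of 450000 nM to 2000000 nM.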

Compound 3, half-maximal cytotoxic concentration: > 1000000 nM
Compound 3: no number, only a limit; the forecaster's own chance of this, stated with the estimate: 60%; the middle value lies on the limit itself.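

In this assay, compound 2 and compound 3 both stand at a limit and not at a number, so the step between them cannot be read: the limit of > 1000000 nM in this assay, at which 2 of the 3 values shown sit.

Hydrogen in place of methoxy, ortho to a large group, therefore brings no reading below that limit, though any change hidden beyond it stays unseen. The informative comparison lies at the amine nitrogen, where tert-butoxycarbonyl in place of hydrogen gives an at least 2.6-fold higher number from compound 1 to compound 3 (0.42 log units; beyond the scatter), and this size is only a lower bound.

On these data alone, whether methoxy on the ring matters when the amine nitrogen carries hydrogen, as in compound 1, stays open. Also open, as far as these compounds go, is whether a smaller acetyl group on that nitrogen, or a chlorine in place of methoxy, would give a value that can be read as a number.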